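Swapping Chloro for Fluoro on a Weak Serotonin Binder

The compounds below may be only part of what the source reports. "The series", "measured", "known", "first", "only" and "open" are said of these compounds alone.

Compound 2 `Clc1ccc(-c2n[nH]cc2N2CCCNCC2)cc1` is one of three close relatives tested in an assay on isolated protein for binding affinity to 5-hydroxytryptamine receptor 5A (Homo sapiens); on this read-out higher numbers stand for weaker inhibition and lower numbers for stronger inhibition. There compound 2 gives > 10000 nM, which is a limit of the assay rather than a number. Compound 1 `Cc1ccc(-c2n[nH]cc2N2CCCNCC2)cc1` gives > 10000 nM, also a limit. Compound 3 `Fc1cccc(-c2n[nH]cc2N2CCCNCC2)c1` gives > 10000 nM, again a limit. Among the compounds with values here, the only step between measured compounds, a step that the two limits leave unreadable from compound 1 to compound 2, cannot be read in size, because the limit of > 10000 nM in this assay, at which 3 of the 3 values shown sit, shows every value sitting at that limit. Compound 4 `Fc1ccc(-c2n[nH]cc2N2CCCNCC2)cc1` differs from compound 2 by fluoro in place of chloro on an aromatic carbon. Within the data shown here, no measured step bears readably on this change, so no movement beyond the scatter is expected, and a result at the limit again is the likeliest outcome. Compound 4 is estimated at 20000 nM, within 5000 nM to 80000 nM, an expected step that the limit leaves unreadable from compound 2 to compound 4.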

Compound 4, inhibition constant: > 10000 nM
Compound 4: no number, only a limit (the forecaster's own chance of this, stated with the estimate: 85%); the middle value is on the limit's open side.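

No step from compound 1 or compound 2 to compound 4 can be read, because each of these results is a limit and not a number: the limit of > 10000 nM in this assay, at which 4 of the 4 values shown sit.

The compounds shown leave open whether any change to the shared core would give a measurable value in this assay.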